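Macrocyclic aldehydes: tolerance in a liver cell line

A few compounds are considered here, and "the series" means these few. Any claim that something is new, unique, unknown or untested is made for them only; others in the source may bear on it.

Compound 1 `CC(C)C[C@@H]1NC(=O)[C@@H](NC(=O)OCc2ccccc2)Cc2cn(nn2)CCCNC(=O)CC[C@@H](C=O)NC1=O`: > 100000 nM
Compound 2 `O=C[C@@H]1CCC(=O)NCCCn2cc(nn2)C[C@H](NC(=O)OCc2ccccc2)C(=O)N[C@@H](CC2CCCCC2)C(=O)N1`: > 100000 nM
Compound 3 `CC(C)C[C@@H]1NC(=O)[C@@H](NC(=O)OCc2ccccc2)Cc2cn(nn2)CCCCCCNC(=O)CC[C@@H](C=O)NC1=O`: > 100000 nM

Three macrocyclic aldehydes have been measured in an ADME assay on HG23 cells (Homo sapiens) for cytotoxicity, with a stated time of 72 h; a higher number here means that more compound is tolerated, a lower number that less compound is tolerated. Compound 1 gives > 100000 nM in this assay, which is a limit of the assay and not a number. Compound 2 gives > 100000 nM in this assay, again a limit. Compound 3 gives > 100000 nM in this assay, also a limit. All three sit at the limit of > 100000 nM in this assay, at which 3 of the 3 values shown sit.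

Compound 2 is derived from compound 1 by cyclohexyl in place of isopropyl on a saturated chain carbon bound to a saturated ring carbon. The step that the two limits leave unreadable from compound 1 to compound 2 cannot be read, as both ends are limits. Compound 3 shares this kind of macrocycle with compound 1, but the difference between the two cores is not broken down here.

Compound 4 `O=C[C@@H]1CCC(=O)NCCCCCCn2cc(nn2)C[C@H](NC(=O)OCc2ccccc2)C(=O)N[C@@H](CC2CCCCC2)C(=O)N1` has not yet been measured. It differs from compound 3 by cyclohexyl in place of isopropyl on a saturated chain carbon bound to a saturated ring carbon, the same change as that from compound 1 to compound 2, at the same place. Since compound 1, compound 2 and compound 3 all sit at the limit of > 100000 nM in this assay, at which 3 of the 3 values shown sit, and the change from compound 1 to compound 2 left the value at the limit, compound 4 is expected to remain at the limit too, so that the expected step of a number no higher from compound 3 to compound 4 (the limit leaves the size open) is essentially flat. The estimate for compound 4 in this assay is therefore 100000 nM, with a range from 50000 nM to 300000 nM, most likely reported as a limit.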

Compound 4, half-maximal cytotoxic concentration: > 100000 nM
Compound 4: no number, only a limit; the forecaster's own chance of this, stated with the estimate: 90%; the middle value sits exactly at the limit.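

In this assay compound 4 gives > 100000 nM, which is a limit of the assay and not a number. Compound 3 also stands at a limit, so no step can be read from compound 3 to compound 4, and the series gives only one reading: the limit of > 100000 nM in this assay, at which 4 of the 4 values shown sit.

The compounds shown leave open how much compound the cells would tolerate beyond that limit, and whether cyclohexyl in place of isopropyl changes this at all.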